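Volume of distribution after swapping the amide acyl group

A few compounds are considered here, and "the series" means these few. Any claim that something is new, unique, unknown or untested is made for them only; others in the source may bear on it.

Three compounds have been run in an ADME assay on the whole organism (Mus musculus) for pharmacokinetics, using cassette dosing; on this read-out higher numbers stand for wider distribution into tissues and lower numbers for narrower distribution. Compound 1 `Cc1ccc(C(=O)Nc2cn3ncnc3c(O[C@H]3CCN(C(=O)CC(C(F)(F)F)C(F)(F)F)[C@@H](C)C3)c2C)cn1` gives 0.8 L/kg. Compound 2 `Cc1ccc(C(=O)Nc2cn3ncnc3c(CN3CCN(C(=O)C4CCCC4)[C@@H](C)C3)c2C)cn1` gives 0.77 L/kg, the lowest of the three numbers, though within the scatter of compound 1. Compound 3 `Cc1ccc(C(=O)Nc2cc(F)cc(CN3CCN(C(=O)C4CCCC4)[C@@H](C)C3)c2C)cn1` gives 1.6 L/kg, a step beyond the scatter above compound 2.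

Compound 4 `Cc1ccc(C(=O)Nc2cn3ncnc3c(CN3CCN(C(=O)CC(C(F)(F)F)C(F)(F)F)[C@@H](C)C3)c2C)cn1` is compound 2 with one change: 3,3,3-trifluoro-2-(trifluoromethyl)propyl in place of cyclopentyl on a carbonyl carbon. For the measured compounds named here, no measured pair covers this exact change. Going by the values given here, the entering group is the one carried by compound 1, which sits within the scatter of compound 2 in this assay, so no step beyond the scatter is expected from compound 2 to compound 4, as expressed by a 1.1-fold higher number from compound 2 to compound 4 (0.04 log units; within the scatter). Compound 4 is estimated at 0.85 L/kg, with a range from 0.5 L/kg to 1.5 L/kg.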

Compound 4, volume of distribution at steady state: 1.1 L/kg
Compound 4: middle estimate off by 1.3-fold (0.11 log units), on the low side; measured number inside the range.
By their numbers in this assay, from the lowest: compounds 2, 1, 4 and 3 (each within the scatter of the next, the first and the last beyond it).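

In this assay the acyl position now has its first comparison differing in one place, with a 1.4-fold higher number from compound 2 to compound 4 (0.15 log units; within the scatter) for 3,3,3-trifluoro-2-(trifluoromethyl)propyl in place of cyclopentyl on a carbonyl carbon. On the core of compound 2, an open fluorinated chain can therefore replace a carbon-only ring without a step beyond the scatter. No evidence on the reason for this result is available.

As far as these compounds go, whether an acyl group carrying an amine or a carboxylic acid would move the read-out beyond the scatter remains open. So does whether this exchange reads the same on the core of compound 3.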